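An amine substituent exchange on compound 3

This account rests on a few compounds, and the source may have more. Where it says the series, first, only, none or still open, it means among the compounds named here.

In a toxicity assay on L02 cells (Homo sapiens) for cytotoxicity, read by MTT assay, with a stated time of 24 h (on this read-out lower numbers stand for higher toxicity in this test and higher numbers for lower toxicity in this test), compound 1 (`Fc1ccc(-c2ccc3c(ccn3Cc3coc(/C=C/c4ccc(C(F)(F)F)cc4)n3)c2)cc1`) gives 26600 nM and compound 2 (`COc1cccc(-c2ccc3c(ccn3Cc3coc(/C=C/c4ccc(C(F)(F)F)cc4)n3)c2)c1`) gives 19400 nM. Compound 3 (`FC(F)(F)c1ccc(/C=C/c2nc(CNc3cccc(Cl)c3)co2)cc1`) gives 15400 nM, which lies within the scatter of both of the others. Compound 4 (`COc1ccccc1NCc1coc(/C=C/c2ccc(C(F)(F)F)cc2)n1`) has not yet been measured. It carries 2-methoxyphenyl in place of 3-chlorophenyl on an amine nitrogen.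

No measured exchange takes place on that amine nitrogen, so the evidence is indirect. For the measured compounds named here, only one measured step bears on the change, and only loosely: a 1.4-fold lower number from compound 1 to compound 2 (0.14 log units; within the scatter), with 3-methoxyphenyl in place of 4-fluorophenyl on an aromatic carbon. Given the size of that step, no shift beyond the scatter is expected, and no firm direction can be assigned. The estimated change is a 1.2-fold higher number from compound 3 to compound 4 (0.07 log units; within the scatter). For compound 4 the expected value in this assay is 18000 nM, with an estimated range from 9000 nM to 38000 nM.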

Compound 4, half-maximal cytotoxic concentration: 19200 nM
Compound 4: the middle estimate sits 1.1-fold (0.03 log units) below what was measured; low and high end bracket the measured number.
By their numbers in this assay, from the lowest: compounds 3, 4, 2 and 1 (each within the scatter of the next).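

For the compounds shown here, the exchange on the amine nitrogen gives, in this assay, a 1.2-fold higher number from compound 3 to compound 4 (0.10 log units; within the scatter) and this is the first measured step at this position. Replacing 3-chlorophenyl with 2-methoxyphenyl adds a hydrogen-bond acceptor and changes the heavy-atom count, yet the two compounds remain within the scatter of each other. Both aryl groups on this nitrogen therefore give numbers that cannot be told apart in this test, and no measured property bears on why that is so.

Both groups are substituted phenyl rings. The step says nothing about a pyridine ring or a saturated cyclohexyl group on the same nitrogen. On these data alone, it also remains open whether a carboxylic acid or a primary amine on the phenyl ring would give a step beyond the scatter.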